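The compounds below may be only part of what the source reports. "The series", "measured", "known", "first", "only" and "open" are said of these compounds alone.

Among the measured compounds shown here, compound 3, with the structure `Cc1cccc(-c2cn3ccnc3c(-c3ccc4ncn(Cc5ccccc5)c4c3)n2)c1`, sits at the bottom of the three numbers so far. In a functional assay on NCI/ADR-RES cells (Homo sapiens) for inhibition, read by sulforhodamine B assay, with a stated time of 48 h, tested at 10 uM (a lower number here means less inhibition, a higher number more inhibition at the concentration tested (going by the name of the read-out)), compound 3 gives 12.1%. Its nearest neighbour is compound 1, `O=Cc1ccc(-c2cn3ccnc3c(-c3ccc4ncn(C5CCCCC5)c4c3)n2)cc1`, which in this assay gives 37.4%. Furthest away is compound 2, `CCc1ccc(-c2cn3ccnc3c(-c3ccc4ncn(Cc5ccccc5)c4c3)n2)cc1`, which in this assay gives 41.2%; the one recorded step, a number 29.1 percentage points lower from compound 2 to compound 3 (beyond the scatter), shows how much the change from 4-ethylphenyl to 3-methylphenyl cost.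

The unmeasured compound 4 has the structure `O=Cc1ccc(-c2cn3ccnc3c(-c3ccc4ncn(Cc5ccccc5)c4c3)n2)cc1`. It differs from compound 3 in one place: 4-formylphenyl in place of 3-methylphenyl on an aromatic carbon. For the measured compounds named here, only one measured step touches the same position, and it is the step from compound 2 to compound 3 already named; it was modest in size and went downward when 3-methylphenyl replaced 4-ethylphenyl. Compound 1 carries the same 4-formylphenyl that enters here, though on a different core substituent, and its value stands well above that of compound 3. Both observations point the same way: leaving 3-methylphenyl is expected to recover most of the lost inhibition, so an upward step of about a number 23.9 percentage points higher from compound 3 to compound 4 (beyond the scatter) is expected. Compound 4 is therefore estimated at 36%, with a range from 20% to 52%.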

Compound 4, a percentage reported as inhibition, at one concentration (the size of the read-out at that concentration, not a potency): 37.4%
Beside the measured number, compound 4's estimate is 1.4 percentage points below it; measured number inside the range.
By their numbers in this assay, from the lowest: compound 3; then compounds 1, 4 and 2 (each within the scatter of the next).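

With 4-formylphenyl in place of 3-methylphenyl on the shared core, this assay shows a number 25.3 percentage points higher from compound 3 to compound 4 (beyond the scatter) and thus that the low value of compound 3 does not follow from every replacement of 4-ethylphenyl at this aromatic carbon. Formyl in place of ethyl gives a number 3.8 percentage points lower from compound 2 to compound 4 (within the scatter) and leaves these two substituted phenyl groups indistinguishable here, so among the four compounds shown, only compound 3, the one with 3-methylphenyl, stands apart from the others. The other site also gets its first reading, as benzyl in place of cyclohexyl on the aromatic nitrogen gives no change at the digits printed from compound 1 to compound 4 (within the scatter) with 4-formylphenyl held constant, although this single pair says nothing about that exchange alongside any other phenyl group.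

The compounds shown cannot separate the identity of the methyl group from where it sits on the phenyl ring, a question that 4-methylphenyl and 3-formylphenyl would address directly. On these data alone, it also remains open whether a phenyl group bearing an amine or a carboxylic acid would stay with compounds 2 and 4 or fall towards compound 3. No evidence is available to explain these differences.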